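A few compounds are considered here, and "the series" means these few. Any claim that something is new, unique, unknown or untested is made for them only; others in the source may bear on it.

Compound 1 (`CCCCCCCCCCCCCCC[C@@H](O)[C@@H](N)[C@@H](C)O`) carries a long saturated chain, and in a functional assay on SW1573 cells (Homo sapiens) for antiproliferative activity, read by sulforhodamine B assay, with a stated time of 48 h (a higher number here means a weaker inhibitor of growth, a lower number a stronger inhibitor of growth), compound 1 gives 17000 nM. Compound 2 (`CCCCCCCCC[C@@H](O)[C@@H](N)[C@@H](C)O`), which lacks the hexyl portion of that chain, gives 17000 nM, so compound 1 stands level with it. Within the data shown here, that pair provides the only measured step, no change at the digits printed from compound 1 to compound 2 (within the scatter).

Compound 3 (`CCCCCCCCCCCCCCC[C@@H](O)[C@@H](N)[C@@H](C)CC`) has not yet been measured. Its difference is ethyl in place of hydroxy on a saturated chain carbon bound to two saturated chain carbons. The measured step concerns a different place in the structure, so it offers only weak guidance, and no measurement shows what replacing this hydroxy does. No step beyond the scatter is therefore expected in this assay, no direction can be favoured, and the range must stay wide. For compound 3 the estimate is 12000 nM, with an expected range from 4000 nM to 35000 nM. This estimate means an expected 1.4-fold lower number from compound 1 to compound 3 (0.15 log units; within the scatter).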

Compound 3, concentration for 50% growth inhibition: 3400 nM
Estimate against measurement, compound 3: 3.5-fold (0.55 log units) above, outside the stated range (below it).
By their numbers in this assay, from the lowest: compound 3; then compounds 1 and 2 (each within the scatter of the next).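

The step at the far end of the long chain left the number unmoved, but this change near the other end of the molecule does register: ethyl in place of hydroxy in this assay gives a step beyond the scatter (a 5.0-fold lower number from compound 1 to compound 3 (0.70 log units; beyond the scatter)). The hydroxy on this saturated chain carbon is therefore not required for growth inhibition in compound 3, and the number here responds to what this position carries. No measurement at hand accounts for the size or direction of this step.

As far as these compounds go, the hydroxy left and the ethyl entered in a single change, so it remains open which of the two matters, a question that a plain hydrogen or a methyl at this place could help to settle. Also open, from the compounds shown here alone, are how a propyl or an amine would behave here, and whether the same change on the shorter chain of compound 2 would give a similar step.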